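This account rests on a few compounds, and the source may have more. Where it says the series, first, only, none or still open, it means among the compounds named here.

Measured so far in an ADME assay on J774 cells (Mus musculus) for cytotoxicity, read by resazurin assay, with a stated time of 72 h (a higher number here means that more compound is tolerated, a lower number that less compound is tolerated), each reading a limit of the assay and not a number:

- Compound 1 `C/C(=N\Nc1nc(-c2ccccc2)cs1)c1ccc(Cl)c(Cl)c1`: > 50000 nM
- Compound 2 `C/C(=N\Nc1nc(-c2ccccc2)c(C)s1)c1ccc(Cl)c(Cl)c1`: > 50000 nM
- Compound 3 `C/C(=N\Nc1nc(-c2ccc(Cl)cc2Cl)cs1)c1ccc(Cl)c(Cl)c1`: > 50000 nM

The whole set stands at one reading, (the limit of > 50000 nM in this assay, at which 3 of the 3 values shown sit). Compound 2 has only a limit, > 50000 nM, and so shares that position with the other two compounds.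

Compound 4 `C/C(=N\Nc1nc(-c2ccc(Br)cc2)c(C)s1)c1ccc(Cl)c(Cl)c1` is compound 2 with a single change, bromo in place of hydrogen on an aromatic carbon, which turns phenyl into 4-bromophenyl.

Among the measured compounds shown here, two measured steps bear on this change. The closer one also alters the phenyl group, replacing it with 2,4-dichlorophenyl, and it is a step that the two limits leave unreadable from compound 1 to compound 3. The other places methyl in place of hydrogen on an aromatic carbon, and it is a step that the two limits leave unreadable from compound 1 to compound 2. Neither step has a size that can be read, so they offer no measured effect to carry over. Neither of them moved a compound off the limit, however, so no step beyond the scatter is expected in this assay.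

The expected change is a number no higher from compound 2 to compound 4 (the limit leaves the size open). For compound 4 the estimate is 50000 nM, with an expected range from 20000 nM to 100000 nM.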

Compound 4, half-maximal cytotoxic concentration: > 50000 nM
Compound 4: no number, only a limit; the forecaster's own chance of this, stated with the estimate: 70%; the middle value lies on the limit itself.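

Compound 2 and compound 4 both sit at a limit of this assay and not at a number, so no step can be read between them. The compounds shown leave open where the half-maximal cytotoxic concentration of any of them lies, and whether the bromo group changes it at all, since the whole set stands at one reading: the limit of > 50000 nM in this assay, at which 4 of the 4 values shown sit.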